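This account rests on a few compounds, and the source may have more. Where it says the series, first, only, none or still open, it means among the compounds named here.

Compound 1, `Cc1cccc(NC(=O)CSc2nnc(-c3ccoc3C)n2Cc2ccco2)c1C`, in a functional assay on CHO cells for antagonist activity at Orexin receptor type 2 (Homo sapiens), read by FLIPR and calcium flux (on this read-out higher numbers stand for weaker inhibition and lower numbers for stronger inhibition), gives > 15800 nM, which is a limit of the assay and not a number.
Compound 2, `COc1ccc(C)cc1NC(=O)CSc1nnc(-c2ccoc2C)n1Cc1ccco1`, in this assay gives 15.9 nM.
Compound 3, `Cc1occc1-c1nnc(SCC(=O)Nc2cccc(F)c2)n1Cc1ccco1`, in this assay gives 501 nM.

Among the two numbers shown, compound 3 stands highest; its nearest neighbour is compound 2, and the step of a 32-fold higher number from compound 2 to compound 3 (1.50 log units; beyond the scatter) lies beyond the scatter. Compound 4, `COc1ccc(NC(=O)CSc2nnc(-c3ccoc3C)n2Cc2ccco2)cc1`, is not yet measured. It differs from compound 3 in one place: 4-methoxyphenyl in place of 3-fluorophenyl on an amide-type nitrogen.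

Within the data shown here, three measured steps bear on this position. The change an at least 990-fold lower number from compound 1 to compound 2 (2.99 log units; beyond the scatter) and the change an at least 31-fold lower number from compound 1 to compound 3 (1.49 log units; beyond the scatter) both show that the group on the amide-type nitrogen moves the number in this assay strongly, and a 32-fold higher number from compound 2 to compound 3 (1.50 log units; beyond the scatter) shows the same from the other side. The two compounds with a methoxy-bearing aryl or a fluorine-bearing aryl both sit far below the limit seen for compound 1, with compound 2 the lowest. Compound 4 is therefore expected to give a step of a 3.3-fold lower number from compound 3 to compound 4 (0.52 log units; beyond the scatter), landing between compound 3 and compound 2. The estimate for compound 4 in this assay is 150 nM, with a range from 30 nM to 800 nM.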

Compound 4, inhibition constant: 200 nM
Beside the measured number, compound 4's estimate is 1.3-fold (0.12 log units) below it, and the stated range covers the measured number.
By their numbers in this assay, from the lowest: compound 2; then compound 4; then compound 3. At a limit, above all of these: compound 1.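

In this assay, the step of a 2.5-fold lower number from compound 3 to compound 4 (0.40 log units; beyond the scatter) is modest but beyond the scatter, and it is far smaller than the other changes seen at this amide-type nitrogen. A methoxy group on the aryl ring is not enough on its own to reach compound 2, since the step of a 13-fold higher number from compound 2 to compound 4 (1.10 log units; beyond the scatter) is large, while the step of an at least 79-fold lower number from compound 1 to compound 4 (1.89 log units; beyond the scatter) places 4-methoxyphenyl well clear of 2,3-dimethylphenyl, although that step rests on a limit and gives only a bound. Compound 1 stands at a limit of the assay and not at a number: the limit of > 15800 nM in this assay, at which 1 of the 4 values shown sits.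

The compounds shown do not separate the contributions of the methoxy and methyl groups in 2-methoxy-5-methylphenyl. On these data alone, how an unsubstituted phenyl, a 2-methoxyphenyl or a 3-methylphenyl group would compare on this nitrogen remains open.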